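A Second Chloro on the Core of Compound 2

A few compounds are considered here, and "the series" means these few. Any claim that something is new, unique, unknown or untested is made for them only; others in the source may bear on it.

In a functional assay on MOLT-4 cells (Homo sapiens) for cytotoxicity, read by sulforhodamine B assay, with a stated time of 48 h (on this read-out higher numbers stand for lower toxicity in this test and lower numbers for higher toxicity in this test), compound 2 `ClCc1cccc(Cn2cnc3c(Cl)ncnc32)c1` stands at the highest of the two numbers seen, as compound 2 gives 89100 nM. The nearest is compound 1 `ClCc1ccccc1Cn1cnc2c(Cl)nc(Cl)nc21`, which in this assay gives 3540 nM, a gap beyond the usual scatter; compound 1 and compound 2 differ in more than one place, so no single change can be read from the pair. Compound 3 `ClCc1cccc(Cn2cnc3c(Cl)nc(Cl)nc32)c1` differs from compound 2 by chloro in place of hydrogen on an aromatic carbon. Compound 3 is expected to give a lower number, with a step of a 5.9-fold lower number from compound 2 to compound 3 (0.77 log units; beyond the scatter) of moderate size. The estimate for compound 3 is 15000 nM, within a range of 4000 nM to 60000 nM.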

Compound 3, concentration lethal to 50% of the cells: > 100000 nM
Compound 3: a limit, no number; the forecaster's own chance of this, stated with the estimate: 5%; at least 6.6-fold (0.82 log units) between middle value and limit.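

In this assay compound 3 gives > 100000 nM, which is a limit and not a number. Chloro in place of hydrogen on this aromatic carbon, between two ring nitrogen atoms, therefore does not bring the number down on this core: the change reads as an at least 1.1-fold higher number from compound 2 to compound 3 (0.05 log units; that floor lies within the scatter). How large the step really is stays unknown, because the value sits at a limit: the limit of > 100000 nM in this assay, at which 1 of the 3 values shown sits.

The compounds shown leave open whether an amine or a methoxy group on the same carbon would give a lower number. They also leave open how far the value of compound 3 lies past its limit.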